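This account rests on a few compounds, and the source may have more. Where it says the series, first, only, none or still open, it means among the compounds named here.

Measured compounds so far:

Compound 1, `NC(=O)c1ccc2[nH]c(-c3ccc(OC4CCCNC4)cc3)nc2c1`: in a physicochemical assay for solubility, with a stated time of 3 days, at pH 7 (a lower number here means a less soluble compound, a higher number a more soluble compound), compound 1 gives > 400000 nM, which is a limit of the assay and not a number.
Compound 2, `NC(=O)c1ccc2[nH]c(-c3ccc(OCCCN4CCCCC4)cc3)nc2c1`: in this assay compound 2 gives > 400000 nM, again a limit of the assay.
Compound 3, `NC(=O)c1ccc2[nH]c(-c3ccc(OC4CCNCC4)cc3)nc2c1`: in this assay compound 3 gives "not determined" (no result reported).

Within the data shown here, compound 1 therefore stands at a limit rather than at a measured number, as does the one other value reported, a situation summarised by the limit of > 400000 nM in this assay, at which 2 of the 3 values shown sit; compound 3 contributes no number to compare against. Among the measured compounds shown here, the single step between measured compounds, a step that the two limits leave unreadable from compound 1 to compound 2, runs from one limit to another and its size cannot be read.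

The compound still to be measured is compound 4, `CN1CCC(Oc2ccc(-c3nc4cc(C(N)=O)ccc4[nH]3)cc2)CC1`. It differs from compound 1 in one place: 1-methylpiperidin-4-yl in place of piperidin-3-yl on an oxygen on an aromatic ring. For the measured compounds named here, no measured step bears on this change in a readable way, so the expectation rests only on where compound 1 stands. With compound 1 already at the limit, the estimated step of a number no higher from compound 1 to compound 4 (the limit leaves the size open) is expected to be none beyond the scatter. Compound 4 is accordingly expected to give 400000 nM in this assay, with an estimated range from 100000 nM to 400000 nM, and most probably the result will again be reported only as a limit.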

Compound 4, solubility: > 400000 nM
Compound 4 was reported as a limit; the forecaster's own chance of this, stated with the estimate: 75%; the middle value lies on the limit itself.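

Compound 4 stands at a limit in this assay, as do compound 1 and compound 2, and no step among these three compounds can be read. The compounds shown leave open whether any of these changes on the oxygen alters solubility in this assay at all.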